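Sulfone series: swapping ester for acid and halogen

The compounds below may be only part of what the source reports. "The series", "measured", "known", "first", "only" and "open" are said of these compounds alone.

Measured compounds:
compound 1 `COc1cc(OC)c(/C=C/S(=O)(=O)Cc2ccc(OC)c(N)c2)c(OC)c1`: 4 nM
compound 2 `COC(=O)C(Nc1cc(CS(=O)(=O)/C=C/c2c(OC)cc(OC)cc2OC)ccc1OC)c1ccccc1`: 75 nM
compound 3 `COC(=O)C(Nc1cc(CS(=O)(=O)/C=C/c2c(OC)cc(OC)cc2OC)ccc1OC)c1ccc(F)cc1`: 300 nM

These values come from a functional assay on DU-145 cells (Homo sapiens) for cytotoxicity, read by trypan blue exclusion, with a stated time of 96 h; a higher number here means a weaker inhibitor, a lower number a stronger inhibitor. Compound 3 gives the highest number of the three, with compound 2 nearest and compound 1 furthest. Compound 4 `COc1cc(OC)c(/C=C/S(=O)(=O)Cc2ccc(OC)c(NC(C(=O)O)c3ccc(Cl)cc3)c2)c(OC)c1` differs from compound 3 in one place: carboxy(4-chlorophenyl)methyl in place of (4-fluorophenyl)(methoxycarbonyl)methyl on a nitrogen on an aromatic ring. Among the measured compounds shown here, two measured steps bear on it. Substitution on the ring nitrogen gave a 19-fold higher number from compound 1 to compound 2 (1.27 log units; beyond the scatter) and a 75-fold higher number from compound 1 to compound 3 (1.88 log units; beyond the scatter), and the halogen alone gave a 4.0-fold higher number from compound 2 to compound 3 (0.60 log units; beyond the scatter). For the measured compounds named here, no measured step covers the acid in place of the ester or the chloro in place of fluoro, so in this assay compound 4 is expected to stay near compound 3, with a modest step of a 1.5-fold higher number from compound 3 to compound 4 (0.18 log units; within the scatter) toward a higher number. The estimate for compound 4 is 450 nM, within 120 nM to 2000 nM.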

Compound 4, half-maximal inhibitory concentration: 400 nM
The estimate for compound 4 lay 1.1-fold (0.05 log units) above the measured number, and the stated range covers the measured number.
By their numbers in this assay, from the lowest: compound 1; then compound 2; then compounds 3 and 4 (each within the scatter of the next).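

In this assay, carboxy(4-chlorophenyl)methyl in place of (4-fluorophenyl)(methoxycarbonyl)methyl on the nitrogen gave a 1.3-fold higher number from compound 3 to compound 4 (0.12 log units; within the scatter), so this double change stays within the scatter. The same group gave a 5.3-fold higher number from compound 2 to compound 4 (0.73 log units; beyond the scatter) and a 100-fold higher number from compound 1 to compound 4 (2.00 log units; beyond the scatter), so substitution on this nitrogen with an acid, like that with an ester, remains far from the free amine of compound 1. No measured evidence explains these steps.

As far as these compounds go, the acid and the chloro arrive together, so their separate contributions stay unknown. From the compounds shown here alone, how a primary amide or a bromo substituent would read at this position also remains open.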